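A few compounds are considered here, and "the series" means these few. Any claim that something is new, unique, unknown or untested is made for them only; others in the source may bear on it.

Two compounds of this series have numbers in an assay on isolated protein for inhibition of Aromatase (Homo sapiens), read by fluorescence and colorimetric assay, with a stated time of 30 min; a lower number here means a stronger inhibitor, a higher number a weaker inhibitor. Compound 1 `N#Cc1ccc(C(c2ccc(C#N)cc2)n2cc(C3CCCCC3)nn2)cc1` gives 19300 nM in this assay. Compound 2 `CCCCCCCc1cn(Cc2ccc(C#N)cc2)nn1` gives 3070 nM in this assay, the lower of the two numbers; compound 1 sits beyond the scatter above it. Compound 3 `N#Cc1ccc(Cn2cc(C3CCCCC3)nn2)cc1` differs from compound 2 by cyclohexyl in place of heptyl on an aromatic carbon. For the measured compounds named here, no measured pair shows this exchange, so the size of the step rests on expectation alone: the step is expected to stay within the scatter, with no clear direction, as a 1.1-fold higher number from compound 2 to compound 3 (0.06 log units; within the scatter). Compound 3 is therefore estimated at 3500 nM, with a range from 1200 nM to 10000 nM.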

Compound 3, half-maximal inhibitory concentration: 10700 nM
Beside the measured number, compound 3's estimate is 3.1-fold (0.49 log units) below it, and the stated range ends below it.
By their numbers in this assay, from the lowest: compound 2; then compounds 3 and 1 (each within the scatter of the next).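

On this aromatic carbon the group matters in this assay: cyclohexyl in place of heptyl gives a 3.5-fold higher number from compound 2 to compound 3 (0.54 log units; beyond the scatter), so the open chain and the six-membered ring are not interchangeable here, though the step is modest. With cyclohexyl held, hydrogen in place of 4-cyanophenyl on the saturated chain carbon gives a 1.8-fold lower number from compound 1 to compound 3 (0.26 log units; within the scatter), a step that cannot be told from scatter. Nothing at hand explains either step. Still open, from the compounds shown here alone, is how a shorter chain, or an amine or carboxylic acid at the end of the heptyl chain, would read at this position.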